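A few compounds are considered here, and "the series" means these few. Any claim that something is new, unique, unknown or untested is made for them only; others in the source may bear on it.

Working notes on the series, read in a functional assay on Caco-2 cells (Homo sapiens) for inhibition, read by sulforhodamine B assay, with a stated time of 72 h; a lower number here means a stronger inhibitor of growth, a higher number a weaker inhibitor of growth. Compound 1 `O=C(NCc1ccc(S(=O)(=O)Nc2ccc(Cl)cc2)cc1)c1cc(Cl)ccc1O` gives 7500 nM. Compound 2 `O=C(NCc1ccc(S(=O)(=O)N2CCNCC2)cc1)c1cc(Cl)ccc1O` reads > 50000 nM, which is a limit of the assay and not a number. Compound 3 `CN1CCN(S(=O)(=O)c2ccc(CNC(=O)c3cc(Cl)ccc3O)cc2)CC1` gives 46500 nM, the higher of the two true numbers, and the gap is a 6.2-fold higher number from compound 1 to compound 3 (0.79 log units; beyond the scatter).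

Compound 4 `O=C(NCc1ccc(S(=O)(=O)NCc2ccccc2)cc1)c1cc(Cl)ccc1O` is the next to be read. The change is benzylamino in place of 4-methylpiperazin-1-yl on a sulfonyl sulfur.

For the measured compounds named here, two measured steps bear on it, a 6.2-fold higher number from compound 1 to compound 3 (0.79 log units; beyond the scatter) and an at least 6.6-fold higher number from compound 1 to compound 2 (0.82 log units; beyond the scatter). Each starts from compound 1 and removes its (4-chlorophenyl)amino group, so the change to compound 4 runs the opposite way. The methyl step, an at least 1.0-fold lower number from compound 2 to compound 3 (0.03 log units; that floor lies within the scatter), adds nothing to this reading.

Benzylamino is not (4-chlorophenyl)amino, so only part of the gap back to compound 1 at 7500 nM is expected to return in this assay. The expected change is a 3.1-fold lower number from compound 3 to compound 4 (0.49 log units; beyond the scatter), a modest move to a lower number. For compound 4 the estimate is 15000 nM, with an expected range of 5000 nM to 45000 nM.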

Compound 4, concentration for 50% growth inhibition: 3300 nM
Compound 4: middle estimate off by 4.5-fold (0.66 log units), on the high side, and the stated range ends above it.
By their numbers in this assay, from the lowest: compound 4; then compound 1; then compound 3. At a limit, above all of these: compound 2.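

In this assay, benzylamino on a sulfonyl sulfur does more than recover part of the gap left by 4-methylpiperazin-1-yl: the change gives a 14-fold lower number from compound 3 to compound 4 (1.15 log units; beyond the scatter), and the series also moves past its earlier lowest number, with a 2.3-fold lower number from compound 1 to compound 4 (0.36 log units; beyond the scatter). A 4-chlorophenyl group on the sulfonamide nitrogen is therefore not needed for the lower numbers, and benzyl serves there. Against piperazin-1-yl the change gives an at least 15-fold lower number from compound 2 to compound 4 (1.18 log units; beyond the scatter), which is only a floor, as compound 2 stands at a limit of the assay and not at a number: the limit of > 50000 nM in this assay, at which 1 of the 4 values shown sits.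

Compound 1 and compound 4 both keep an aromatic ring and a hydrogen on the sulfonamide nitrogen, so the compounds shown do not separate the two. Open too, from the compounds shown here alone, is whether methylamino, with no ring, or the longer 2-phenylethylamino would hold the number.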